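Chloro in place of trifluoromethyl on compound 2

The source may report more compounds than this note shows. Statements on the series, on what has been measured and on what is new or still open speak of the compounds shown alone.

In a functional assay on B16 cells (Mus musculus) for inhibition (on this read-out higher numbers stand for weaker inhibition and lower numbers for stronger inhibition), compound 1 (`Oc1ccc(-c2csc(NCc3ccccc3C(F)(F)F)n2)cc1O`) gives 2600 nM and compound 2 (`Oc1ccc(-c2csc(NCc3cccc(C(F)(F)F)c3)n2)cc1O`) gives 1800 nM on the same scale. These two numbers lie within the usual scatter, so compound 2 stands level with compound 1. Compound 3 (`Oc1ccc(-c2csc(NCc3cccc(Cl)c3)n2)cc1O`) carries chloro in place of trifluoromethyl on an aromatic carbon. Among the compounds with values here, no measured pair shows this swap, so the data offer no direct guide. The estimated step (a 1.1-fold lower number from compound 2 to compound 3 (0.02 log units; within the scatter)) is expected to stay within the scatter. For compound 3 the estimated value is 1700 nM with an expected range from 700 nM to 4000 nM on this scale.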

Compound 3, half-maximal inhibitory concentration: > 50000 nM
Compound 3: only a limit was reported; the forecaster's own chance of this, stated with the estimate: 5%; middle value at least 29-fold (1.46 log units) away from the limit.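

Compounds 1 and 2 stood level, which gave no sign that the group on this ring was critical. In this assay compound 3 gives > 50000 nM, which is a limit of the assay and not a number. Chloro in place of trifluoromethyl on this aromatic carbon gives an at least 27-fold higher number from compound 2 to compound 3 (1.44 log units; beyond the scatter), so a single small swap here can cost nearly all the measurable inhibition.

From the compounds shown here alone, whether methyl, bromo or methoxy on this carbon would keep the inhibition of compound 2 remains open. So does whether chloro would act the same way at the place where compound 1 carries its trifluoromethyl.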